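The source may report more compounds than this note shows. Statements on the series, on what has been measured and on what is new or still open speak of the compounds shown alone.

Of the compounds shown here, three with a shared core have been measured in an assay for inhibition of Indoleamine 2,3-dioxygenase 1 (Homo sapiens), with a stated time of 1 h, tested at 0.1 mM; a lower number here means less inhibition, a higher number more inhibition at the concentration tested (going by the name of the read-out). Compound 1 `CC(C)=NNc1nc2ccccc2s1` gives 30% in this assay. Compound 2 `N#CCCN(N)c1nc2ccccc2s1` gives 2% in this assay. Compound 3 `Cc1ccc2nc(NN)sc2c1` gives 37% in this assay. Compound 3 and compound 1 cannot be told apart, since their two numbers lie within the scatter of each other; compound 2 lies beyond the scatter below compound 3. No pair of these compounds differs in one place only, so the effect of any single change is not known from them.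

Compound 4 `NNC(=O)c1ccc2nc(NN)sc2c1` has not yet been measured. It differs from compound 3 in one place: aminocarbamoyl in place of methyl on an aromatic carbon. Among the measured compounds shown here, no step of this kind appears among the measured compounds, so nothing measured tells how the read-out will move. The expectation is a step from compound 3 to compound 4 of a number 9 percentage points lower from compound 3 to compound 4 (within the scatter), which is not beyond the scatter. Compound 4 is therefore estimated to give 28% in this assay, within a range from 5% to 52%.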

Compound 4, a percentage reported as inhibition, at one concentration (the size of the read-out at that concentration, not a potency): -1%
Beside the measured number, compound 4's estimate is 29 percentage points above it, and the stated range ends above it.
By their numbers in this assay, from the lowest: compounds 4 and 2 (each within the scatter of the next); then compounds 1 and 3 (each within the scatter of the next).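

The series now holds its first pair differing in one place: with aminocarbamoyl in place of methyl on an aromatic carbon of the six-membered ring, this assay shows a number 38 percentage points lower from compound 3 to compound 4 (beyond the scatter). Among the compounds shown here, this aromatic carbon is therefore not indifferent to what it carries, as the earlier compounds could not show. With aminocarbamoyl there, compound 4 gives -1%, which leaves no sign of inhibition at the concentration tested.

Open, from the compounds shown here alone, is how a carboxylic acid, a primary amide or a methoxy group on this same carbon would read out, and so whether the drop follows the whole aminocarbamoyl group or only its terminal amine. No measurement at hand bears on the reason for a step of this size.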